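Side chain change from compound 3 to compound 4

This account rests on a few compounds, and the source may have more. Where it says the series, first, only, none or still open, it means among the compounds named here.

- compound 1 `COc1ccc(C(=O)N(Cc2ccncc2)Cc2cccc(OCCc3cccc(C(F)(F)F)c3)c2)cc1` gives 8900 nM
- compound 2 `COc1ccc(C(=O)N(Cc2ccncc2)Cc2cccc(OCC3CCOCC3)c2)cc1` gives 17700 nM
- compound 3 `COc1ccc(C(=O)N(Cc2ccncc2)Cc2cccc(OCCc3ccccc3)c2)cc1` gives 16900 nM

In a functional assay on KMS-11 cells (Homo sapiens) for antiproliferative activity, read by CellTiter-Glo, with a stated time of 72 h (on this read-out higher numbers stand for weaker inhibition and lower numbers for stronger inhibition), compound 3 is not separated from compound 1 or compound 2, and every step among the three stays within the scatter. Compound 4 `COc1ccc(C(=O)N(Cc2ccncc2)Cc2cccc(OCc3ccc(F)cc3)c2)cc1` differs from compound 3 by 4-fluorophenyl in place of benzyl on a saturated chain carbon bound to an oxygen on an aromatic ring in one place, with 4-fluorophenyl in place of benzyl on a saturated chain carbon bound to an oxygen on an aromatic ring. Three small steps bear on this change, namely a 1.9-fold higher number from compound 1 to compound 3 (0.28 log units; within the scatter) on removing trifluoromethyl, and a 1.0-fold lower number from compound 2 to compound 3 (0.02 log units; within the scatter) and a 2.0-fold higher number from compound 1 to compound 2 (0.30 log units; within the scatter) on replacing the group at this place. The expected change is a 1.2-fold lower number from compound 3 to compound 4 (0.08 log units; within the scatter) and no step beyond the scatter is anticipated in either direction. Compound 4 is estimated at 14000 nM and expected to fall from 6500 nM to 30000 nM on this read-out.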

Compound 4, half-maximal inhibitory concentration: 22700 nM
Compound 4: the middle estimate sits 1.6-fold (0.21 log units) below what was measured; low and high end bracket the measured number.
By their numbers in this assay, from the lowest: compounds 1, 3, 2 and 4 (each within the scatter of the next, the first and the last beyond it).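

In this assay, 4-fluorophenyl at this place stays within the scatter of both benzyl (a 1.3-fold higher number from compound 3 to compound 4 (0.13 log units; within the scatter)) and oxan-4-yl (a 1.3-fold higher number from compound 2 to compound 4 (0.11 log units; within the scatter)). The series now has its first step at this place beyond the scatter (a 2.6-fold higher number from compound 1 to compound 4 (0.41 log units; beyond the scatter)), a modest separation of 3-(trifluoromethyl)benzyl from 4-fluorophenyl, while compound 2 and compound 3 remain within the scatter of both. No evidence available here explains that separation.

Open, going by these compounds, is whether trifluoromethyl alone carries the separation, since the step from compound 1 to compound 3 stays within the scatter. Also open, on these data alone, is how an amine or a carboxylic acid at this place would read in this assay.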